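Aryl variation on a shared core: cytotoxicity notes

This account rests on a few compounds, and the source may have more. Where it says the series, first, only, none or still open, it means among the compounds named here.

Measured so far in an ADME assay on NIH3T3 cells (Mus musculus) for cytotoxicity, read by MTT assay, with a stated time of 24 h; a higher number here means a weaker inhibitor, a lower number a stronger inhibitor:
compound 1 `COc1ccc(/C=N/NC(=O)CSc2nnc(-c3ccncc3)o2)cc1`: 132000 nM
compound 2 `O=C(CSc1nnc(-c2ccncc2)o1)N/N=C/c1ccccc1F`: 142000 nM
compound 3 `O=C(CSc1nnc(-c2ccncc2)o1)N/N=C/c1cc(Cl)ccc1O`: 166000 nM

The three compounds share one core and differ only in the aryl group on the carbon with a double bond to nitrogen. Compound 3 holds the highest of the three numbers, but its gaps to the others are small: a 1.3-fold higher number from compound 1 to compound 3 (0.10 log units; within the scatter) and a 1.2-fold higher number from compound 2 to compound 3 (0.07 log units; within the scatter), both within the scatter, as is a 1.1-fold higher number from compound 1 to compound 2 (0.03 log units; within the scatter). So far every aryl swap at this position has left this assay unmoved.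

Compound 4 `COc1cc(/C=N/NC(=O)CSc2nnc(-c3ccncc3)o2)ccc1O` is the next variant at the same position: 4-hydroxy-3-methoxyphenyl in place of 5-chloro-2-hydroxyphenyl on a carbon with a double bond to nitrogen. All three measured steps bear on it, since each is an aryl exchange at this carbon, and none went beyond the scatter. No step beyond the scatter is therefore expected from compound 3 to compound 4, in either direction, giving an expected 1.0-fold lower number from compound 3 to compound 4 (0.02 log units; within the scatter). Compound 4 is estimated at 160000 nM in this assay, with a range from 80000 nM to 320000 nM.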

Compound 4, half-maximal inhibitory concentration: 148000 nM
Beside the measured number, compound 4's estimate is 1.1-fold (0.03 log units) above it; the range from low to high includes it.
By their numbers in this assay, from the lowest: compounds 1, 2, 4 and 3 (each within the scatter of the next).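

In this assay, within the data shown here, the 4-hydroxy-3-methoxyphenyl group of compound 4, the first aryl group here to carry a hydroxy and a methoxy group on one ring, stays within the scatter of all three earlier compounds (a 1.1-fold lower number from compound 3 to compound 4 (0.05 log units; within the scatter)) (a 1.0-fold higher number from compound 2 to compound 4 (0.02 log units; within the scatter)) (a 1.1-fold higher number from compound 1 to compound 4 (0.05 log units; within the scatter)). The exchange also removes the chlorine of compound 3 without a step beyond the scatter, so four different aryl groups on the carbon with a double bond to nitrogen now give numbers within the scatter of one another. No supporting data are available to account for this flat result.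

Still open, on these data alone, is whether any group at this carbon can produce a step beyond the scatter, such as an aryl ring bearing an amine or a carboxylic acid, or a longer chain in place of the ring. The compounds shown also leave open how the number responds to a change elsewhere on the shared core.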